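Sulfonyl tetralin amines: compound 3 to its methylurea

This account rests on a few compounds, and the source may have more. Where it says the series, first, only, none or still open, it means among the compounds named here.

Values so far in an assay on isolated protein for displacement of a labelled ligand from 5-hydroxytryptamine receptor 6 (Homo sapiens); on this read-out lower numbers stand for stronger inhibition and higher numbers for weaker inhibition:

compound 1 `NC[C@@H]1CCCc2cc(S(=O)(=O)c3cc[nH]c3)ccc21` gives 0.316 nM
compound 2 `NC[C@@H]1CCCc2cc(S(=O)(=O)c3c[nH]c4ccccc34)ccc21` gives 0.0501 nM
compound 3 `O=C(NC[C@@H]1CCCc2cc(S(=O)(=O)c3cccc(F)c3)ccc21)[C@H]1CCCN1` gives 0.631 nM

Compound 3 carries the highest of the three numbers in this assay. The nearest is compound 1, whose value sits within the scatter of compound 3, so no order between those two can be read. Compound 2 stands furthest away, with a value beyond the scatter from compound 3; on the basis of these two numbers compound 2 shows the stronger binding of the pair.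

The next compound, compound 4 `CNC(=O)NC[C@@H]1CCCc2cc(S(=O)(=O)c3cccc(F)c3)ccc21`, keeps the shared core and the fluorophenyl sulfonyl part of compound 3 and differs only at the carbonyl: methylamino in place of pyrrolidin-2-yl on a carbonyl carbon. Put another way, the ((pyrrolidin-2-yl)carbonyl)amino group of compound 3 becomes a (methylcarbamoyl)amino group in compound 4.

Among the measured compounds shown here, no measured pair among the three compounds covers this kind of change, so the direction rests on judgement. A small step in this assay is expected, if anything towards a higher number, and one that may well stay within the scatter; the expected step is a 2.1-fold higher number from compound 3 to compound 4 (0.31 log units; beyond the scatter). Compound 4 is therefore estimated at 1.3 nM in this assay, with a range from 0.4 nM to 5 nM.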

Compound 4, inhibition constant: 0.398 nM
The estimate for compound 4 lay 3.3-fold (0.51 log units) above the measured number; the measured number lies below the stated range.
By their numbers in this assay, from the lowest: compound 2; then compounds 1, 4 and 3 (each within the scatter of the next).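

In this assay, among the compounds shown here, the single change at the carbonyl gives a 1.6-fold lower number from compound 3 to compound 4 (0.20 log units; within the scatter), so the two compounds cannot be ordered on this read-out. This first single-place pair in the series shows that, with the fluorophenyl sulfonyl part held constant, this position tolerates the loss of the five-membered non-aromatic ring and its defined stereocentre without a step beyond the scatter, so neither feature is required for binding at this level in this pair. Nothing measured here accounts for the close values of the two compounds.

As far as these compounds go, it remains open whether the carbonyl-bearing extension matters at all, as compounds 1 and 2 carry the free amine but differ from compound 3 and compound 4 in their sulfonyl part, so a free amine paired with the fluorophenyl sulfonyl part would be the informative comparison. Also open, from the compounds shown here alone, is how far this tolerance extends on the same carbonyl carbon, for example to dimethylamino, to a longer chain such as butylamino, or to a six-membered piperidin-2-yl ring.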